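The source may report more compounds than this note shows. Statements on the series, on what has been measured and on what is new or still open speak of the compounds shown alone.

In a functional assay on MCF7 cells (Homo sapiens) for cytotoxicity, read by MTT assay, with a stated time of 72 h (a higher number here means a weaker inhibitor, a lower number a stronger inhibitor), compound 1 `COc1ccc(-c2ccnc(C(=O)Nc3ccc(Oc4ccnc5[nH]ccc45)cc3)c2)cc1` gives 8210 nM, which marks it as a weak inhibitor of these cells. Compound 2 `O=C(Nc1ccc(Oc2ccnc3[nH]ccc23)cc1)c1cc(-c2ccc(C(F)(F)F)cc2)ccn1`, which carries trifluoromethyl in place of methoxy, gives > 10000 nM, and this is a limit of the assay, not a number. Within the data shown here, the only measured step is an at least 1.2-fold higher number from compound 1 to compound 2 (0.08 log units; that floor lies within the scatter), so the two compounds cannot be told apart on this evidence.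

Compound 3 `O=C(Nc1ccc(Oc2ccnc3[nH]ccc23)c(F)c1)c1cc(-c2ccc(C(F)(F)F)cc2)ccn1` keeps everything in compound 2 except for one change: fluoro in place of hydrogen on an aromatic carbon. This is fluoro in place of hydrogen on an aromatic carbon, ortho to a large group and meta to a large group. Among the measured compounds shown here, no measured step involves this kind of change. The step of an at least 1.2-fold higher number from compound 1 to compound 2 (0.08 log units; that floor lies within the scatter) concerns another group and ends at a limit, so it gives only a weak guide. Starting from the limit of > 10000 nM in this assay, at which 1 of the 2 values shown sits, no change beyond the scatter is expected in this assay, and no direction can be favoured. The expected outcome is a number no higher from compound 2 to compound 3 (the limit leaves the size open). For compound 3 the estimated value is 10000 nM, with an expected range from 4000 nM to 25000 nM.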

Compound 3, half-maximal inhibitory concentration: 8550 nM
The estimate for compound 3 lay 1.2-fold (0.07 log units) above the measured number; low and high end bracket the measured number.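

Fluoro in place of hydrogen, on an aromatic carbon ortho to a large group and meta to a large group, yields a true measured number: in this assay compound 3 gives 8550 nM. The step is an at least 1.1-fold lower number from compound 2 to compound 3 (0.06 log units; that floor lies within the scatter), so this change shows no effect that can be separated from the usual scatter, although a larger effect is not ruled out. Compound 2 has only a limit and not a number, which leaves the true size of the step open: the limit of > 10000 nM in this assay, at which 1 of the 3 values shown sits.

The compounds shown leave open whether fluoro at other places on this ring would give a similar reading, and whether a different group at this same position, such as chloro, methyl or an amine, would move the number beyond the scatter. Going by these compounds, it also remains open whether this fluoro would behave in the same way with methoxy in place of trifluoromethyl on the far aromatic ring.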